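Replacing 4-methylphenyl with 3-chlorophenyl in compound 2

The source may hold more compounds than are shown below. What is called first, only, known or untested is meant among the compounds shown, and "the series" means these compounds.

Compound 1 (`CCNc1cc(-c2ccc(NC(=O)Nc3cccc(Cl)c3)cc2C)ccn1`) gives 4180 nM
Compound 2 (`CCNc1cc(-c2ccc(NC(=O)Nc3ccc(C)cc3)cc2C(F)(F)F)ccn1`) gives 9470 nM

Both compounds were tested in a functional assay on MCF7 cells (Homo sapiens) for cytotoxicity, read by MTT assay, with a stated time of 24 h; on this read-out higher numbers stand for weaker inhibition and lower numbers for stronger inhibition. Compound 2 stands highest of the two at 9470 nM and is thus the weaker inhibitor. Compound 1 lies lower at 4180 nM and the gap between them is beyond the usual scatter.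

Compound 3 (`CCNc1cc(-c2ccc(NC(=O)Nc3cccc(Cl)c3)cc2C(F)(F)F)ccn1`) has not yet been measured. It differs from compound 2 in one place (3-chlorophenyl in place of 4-methylphenyl on an amide-type nitrogen): 3-chlorophenyl in place of 4-methylphenyl on an amide-type nitrogen. Among the measured compounds shown here, no measured pair shows this change alone. For the measured compounds named here, the only guide is compound 1 (4180 nM), which also carries 3-chlorophenyl but differs from compound 3 elsewhere as well. On that single value, a small move toward stronger inhibition is expected in this assay. The expected change (a 1.6-fold lower number from compound 2 to compound 3 (0.20 log units; within the scatter)) is estimated to stay within the scatter. For compound 3 the estimated value is 6000 nM with an expected range from 2500 nM to 12500 nM in this assay.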

Compound 3, half-maximal inhibitory concentration: 1240 nM
Beside the measured number, compound 3's estimate is 4.8-fold (0.68 log units) above it, outside the stated range (below it).
By their numbers in this assay, from the lowest: compound 3; then compound 1; then compound 2.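

In this assay, the change from 4-methylphenyl to 3-chlorophenyl on an amide-type nitrogen can now be read alone, with trifluoromethyl held constant, and it gives a 7.6-fold lower number from compound 2 to compound 3 (0.88 log units; beyond the scatter) and so moves toward stronger inhibition. The new compound also isolates a second change, trifluoromethyl in place of methyl on an aromatic carbon with 3-chlorophenyl held constant, which gives a 3.4-fold lower number from compound 1 to compound 3 (0.53 log units; beyond the scatter) and shows that this aromatic carbon also bears on the cytotoxicity read-out, something compound 1 and compound 2 could not show because they differ in two places. No measurement is available that would explain either step.

The compounds shown leave open whether 3-chlorophenyl in place of 4-methylphenyl would produce a step of similar size with methyl rather than trifluoromethyl on the aromatic carbon, so it cannot be said whether the two changes act independently. They also leave open how the read-out would respond to a different group on the amide-type nitrogen, such as 3-bromophenyl or a phenyl ring carrying a carboxylic acid.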